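A few compounds are considered here, and "the series" means these few. Any claim that something is new, unique, unknown or untested is made for them only; others in the source may bear on it.

Compound 1 `O=c1ccn([C@@H]2O[C@H](COP(=O)(O)OP(=O)(O)O)[C@@H](O)[C@H]2O)c(SCCc2ccccc2)n1`: 2500 nM
Compound 2 `O=c1ccn([C@@H]2O[C@H](COP(=O)(O)O)[C@@H](O)[C@H]2O)c(SCc2ccccc2)n1`: > 100000 nM
Compound 3 `O=c1ccn([C@@H]2O[C@H](COP(=O)(O)O)[C@@H](O)[C@H]2O)c(SCCc2ccccc2)n1`: > 100000 nM

Among the compounds with values here, in an in vitro functional assay on 1321-N1 cells for agonist activity at P2Y purinoceptor 6 (Homo sapiens), read by scintillation proximity assay and inositol phosphate accumulation (on this read-out higher numbers stand for an effect only at larger amounts of compound and lower numbers for an effect already at smaller amounts), compound 1 gives 2500 nM, the only plain number among the three. For compound 2 the assay reports only a limit, > 100000 nM. For compound 3 it likewise reports only a limit, > 100000 nM; this is the limit of > 100000 nM in this assay, at which 2 of the 3 values shown sit. Compound 4 `CNc1nc(=O)ccn1[C@@H]1O[C@H](COP(=O)(O)OP(=O)(O)O)[C@@H](O)[C@H]1O` differs from compound 1 by methylamino in place of phenethylsulfanyl on an aromatic carbon. Neither measured step touches this part of the molecule: an at least 40-fold higher number from compound 1 to compound 3 (1.60 log units; beyond the scatter) comes from a hydrogen atom in place of a group on an oxygen, and a step that the two limits leave unreadable from compound 2 to compound 3 from benzyl in place of phenyl on a saturated chain carbon bound to a sulfur. With nothing that bears directly on the change, a modest weakening is expected, a 2.0-fold higher number from compound 1 to compound 4 (0.30 log units; within the scatter). Compound 4 is therefore estimated at 5000 nM, between 800 nM and 40000 nM.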

Compound 4, half-maximal effective concentration: > 100000 nM
Compound 4: a limit, no number; the forecaster's own chance of this, stated with the estimate: 15%; middle value at least 20-fold (1.30 log units) away from the limit.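

The step of an at least 40-fold higher number from compound 1 to compound 4 (1.60 log units; beyond the scatter) comes with methylamino in place of phenethylsulfanyl on the aromatic carbon between two ring nitrogen atoms. The activity of compound 1 in this assay therefore depends on this position as well as on the outer phosphate group. Compound 4 gives only a limit, not a number, and it is the same limit the other inactive compounds reach: the limit of > 100000 nM in this assay, at which 3 of the 4 values shown sit.

The compounds shown leave open whether the sulfur or the phenethyl chain matters more. A phenethylamino or a methylsulfanyl group at this position would separate the two.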